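A Methoxy Added to the Same Kind of Ring, Twice

A few compounds are considered here, and "the series" means these few. Any claim that something is new, unique, unknown or untested is made for them only; others in the source may bear on it.

Of the compounds shown here, three built on a shared core have been tested in a functional assay on NCI-H460 cells (Homo sapiens) for cytotoxicity, read by MTT assay, with a stated time of 72 h; on this read-out lower numbers stand for stronger inhibition and higher numbers for weaker inhibition. Compound 1 `COc1cc2c(Oc3ccc(NC(=O)c4cc(-c5ccccc5)nc5ccccc45)cc3F)ccnc2cc1OCCCN1CCC(C)CC1` gives 68 nM. Compound 2 `COc1ccc(-c2cc(C(=O)Nc3ccc(Oc4ccnc5cc(OCCCN6CCC(C)CC6)c(OC)cc45)c(F)c3)c3ccccc3n2)cc1` differs from compound 1 by methoxy in place of hydrogen on an aromatic carbon. In this assay compound 2 gives 110 nM, a step of a 1.6-fold higher number from compound 1 to compound 2 (0.21 log units; within the scatter). Compound 3 `COc1cc2c(Oc3ccc(NC(=O)c4cc(-c5ccccc5)nc5ccc(F)cc45)cc3F)ccnc2cc1OCCCN1CCCCC1` gives 32 nM in this assay, the lowest number of the three; how its core differs from the core of compound 1 is not broken down here.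

Compound 4 `COc1cccc(-c2cc(C(=O)Nc3ccc(Oc4ccnc5cc(OCCCN6CCCCC6)c(OC)cc45)c(F)c3)c3cc(F)ccc3n2)c1` has not yet been measured. It differs from compound 3 by methoxy in place of hydrogen on an aromatic carbon. Among the measured compounds shown here, this is the same kind of change as the one from compound 1 to compound 2, but not the same change: in compound 2 the methoxy sits para to a large group, while in compound 4 it sits meta to a large group.

For the measured compounds named here, the earlier step is the only guide available. Since compound 2 showed a step of a 1.6-fold higher number from compound 1 to compound 2 (0.21 log units; within the scatter), the number for compound 4 in this assay is expected to stay near that of compound 3, and the step from compound 3 to compound 4 is expected to be a 1.6-fold higher number from compound 3 to compound 4 (0.19 log units; within the scatter). The estimate for compound 4 is 50 nM. Its likely range is expected to run from 20 nM to 120 nM. Because compound 3 gives 32 nM, compound 4 is expected to remain among the stronger members of this small set.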

Compound 4, half-maximal inhibitory concentration: 1000 nM
Compound 4: the middle estimate sits 20-fold (1.30 log units) below what was measured; the whole stated range lies below it.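

In this assay, the new step is a 31-fold higher number from compound 3 to compound 4 (1.49 log units; beyond the scatter), and it is large, so a methoxy in place of hydrogen on an aromatic carbon is not a harmless change on every core in this series. A step measured on one core therefore did not predict the step on the other, as the two set side by side show: the same change on two cores in this assay, a 1.6-fold higher number (0.21 log units; within the scatter) from compound 1 to compound 2 and a 31-fold higher number (1.49 log units; beyond the scatter) from compound 3 to compound 4, 19-fold (1.29 log units) apart, beyond the scatter of two such steps

What this does not show is why the two steps differ, since two things vary at once: the cores are not the same, and the methoxy does not sit in the same place on the ring in compound 2 and compound 4, where the change reads phenyl to 3-methoxyphenyl. Among the compounds shown here, with only two steps, these two explanations cannot be told apart, and neither step says how a third core would respond.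

The compounds shown leave open whether a 3-methoxyphenyl on the core of compound 1 would bring the same large rise, which would point to the place on the ring rather than the core. They also leave open whether the rise belongs to methoxy itself or would also follow a chlorine or a hydroxyl on the same carbon of the core of compound 3.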